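A few compounds are considered here, and "the series" means these few. Any claim that something is new, unique, unknown or untested is made for them only; others in the source may bear on it.

Compounds measured:
- compound 1 `O=C1C[C@H](O)C[C@@H](/C=C/c2c(Cl)cc(Cl)cc2-c2ccccc2)O1`: 80 nM
- compound 2 `Cc1cc(C)c(/C=C/[C@@H]2C[C@@H](O)CC(=O)O2)c(-c2ccc(F)c(CO)c2)c1`: 49 nM

The two compounds were tested in an assay for inhibition of 3-hydroxy-3-methylglutaryl-coenzyme A reductase (Rattus norvegicus); on this read-out higher numbers stand for weaker inhibition and lower numbers for stronger inhibition. In this assay compound 1 gives 80 nM, the higher of the two numbers, while compound 2 gives 49 nM; the gap between them lies within the scatter of the measurement, so the two cannot be told apart.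

Compound 3 `Cc1cc(C)cc(-c2cc(Cl)cc(Cl)c2/C=C/[C@@H]2C[C@@H](O)CC(=O)O2)c1` has not yet been measured. It differs from compound 1 in one place: 3,5-dimethylphenyl in place of phenyl on an aromatic carbon. The 3,5-dimethylphenyl enters where the phenyl leaves, on an aromatic carbon of a six-membered aromatic ring of carbon only, ortho to a large group and meta to two chloro groups. Among the compounds with values here, no measured pair in this set shows the effect of this change, so the expectation rests on compound 1 alone. The step from compound 1 is expected to be small, a 1.3-fold lower number from compound 1 to compound 3 (0.12 log units; within the scatter), not clearly beyond the scatter in either direction. Compound 3 is therefore estimated at 60 nM, with a range from 20 nM to 180 nM.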

Compound 3, half-maximal inhibitory concentration: 13 nM
For compound 3 the middle estimate is 4.6-fold (0.66 log units) above the measured one; the measured number lies below the stated range.
By their numbers in this assay, from the lowest: compound 3; then compounds 2 and 1 (each within the scatter of the next).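

In this assay, putting 3,5-dimethylphenyl in place of phenyl, on the aromatic carbon ortho to a large group and meta to two chloro groups, gives a 6.2-fold lower number from compound 1 to compound 3 (0.79 log units; beyond the scatter). Within the data shown here, this is the first sign that the inhibition read-out responds to a change at this position, and the step is one that the scatter does not cover. The change adds only carbon, 8 heavy atoms entering where 6 leave, and nothing shown here accounts for the size of the step.

The compounds shown leave open whether a single methyl on the phenyl would give a similar step, and whether ethyl, methoxy or trifluoromethyl groups could stand in for the two methyl groups. They also leave open whether the step would hold on a core other than that of compound 1.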